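The compounds below may be only part of what the source reports. "The series", "measured", "known", "first", "only" and "open" are said of these compounds alone.

Measured in an ADME assay on NHDF cells (Homo sapiens) for cytotoxicity, read by MTT assay, with a stated time of 72 h; a lower number here means a stronger inhibitor, a higher number a weaker inhibitor:
- compound 1 `COc1cccc(/C=C2\CCC/C(=C\c3ccc(Cl)cc3Cl)C2=O)c1OC`: 49200 nM
- compound 2 `COc1cccc(/C=C2\CCC/C(=C\c3cc(OC)c(OC)c(OC)c3)C2=O)c1OC`: 7900 nM
- compound 3 `COc1ccc(/C=C2\CCC/C(=C\c3ccccc3Br)C2=O)cc1OC`: 21800 nM

Compound 3 has the second highest of these three numbers. Compound 1 stands above it and compound 2 below it, and both gaps lie beyond the usual scatter of repeat measurements.

Compound 4 `COc1ccccc1/C=C1\CCC/C(=C\c2ccc(OC)c(OC)c2)C1=O` differs from compound 3 in one place: methoxy in place of bromo on an aromatic carbon, ortho to a large group (methoxy in place of bromo on an aromatic carbon). Among the compounds with values here, no two measured compounds differ in only one place, so this swap has no direct precedent here. The only clue is thin: compound 2, which carries no halogen, gives 7900 nM, a lower number than halogen-bearing compound 3. Compound 4 also carries no halogen, so a small move toward a lower number in this assay is expected, perhaps one no larger than the scatter.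

The estimated change is a 1.6-fold lower number from compound 3 to compound 4 (0.19 log units; within the scatter).

For compound 4 the estimated value is 14000 nM, with an expected range of 6000 nM to 33000 nM.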

Compound 4, half-maximal inhibitory concentration: 18100 nM
For compound 4 the middle estimate is 1.3-fold (0.11 log units) below the measured one; the measured number falls inside the stated range.
By their numbers in this assay, from the lowest: compound 2; then compounds 4 and 3 (each within the scatter of the next); then compound 1.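

In this assay, within the data shown here, the swap of bromo for methoxy, on an aromatic carbon ortho to a large group, gives a 1.2-fold lower number from compound 3 to compound 4 (0.08 log units; within the scatter) and so offers the first direct reading of a single change in this set. At this position, 2-bromophenyl and 2-methoxyphenyl cannot be told apart by this read-out, even though methoxy brings one more heavy atom and a hydrogen-bond acceptor that bromo lacks. Nothing measured here speaks to why the two groups read alike.

One pair cannot show whether the same swap would read the same way with other groups on the rest of the molecule. Going by these compounds, how an amine or a carboxylic acid would read at this position also remains open.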